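This account rests on a few compounds, and the source may have more. Where it says the series, first, only, none or still open, it means among the compounds named here.

Measured so far in a functional assay on KYSE-410 cells (Homo sapiens) for antiproliferative activity, read by MTT assay, with a stated time of 72 h; on this read-out lower numbers stand for stronger inhibition and higher numbers for weaker inhibition:
compound 1 `O=C(c1cc(=O)[nH]c2cc(Br)ccc12)N1CCCCC1`: > 20000 nM (a limit)
compound 2 `O=C(Nc1ccc(Cl)cc1)c1cc(=O)[nH]c2cc(Br)ccc12`: > 20000 nM (a limit)

Neither compound gives a number, and the data hold only (the limit of > 20000 nM in this assay, at which 2 of the 2 values shown sit). Compound 2 stands at > 20000 nM, which is a limit of this assay and not a number.

Compound 3 `O=C(Nc1ccccn1)c1cc(=O)[nH]c2cc(Br)ccc12` keeps the core of compound 2, with pyridin-2-yl in place of 4-chlorophenyl on an amide-type nitrogen.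

Within the data shown here, no measured step shows what such an exchange does, so neither a size nor a direction can be drawn from the data, and no step beyond the scatter is expected in this assay. The expected result is that the new compound also reports only a limit. The estimated change is a number no higher from compound 2 to compound 3 (the limit leaves the size open). For compound 3 the expected value is 20000 nM, with an estimated range of 9000 nM to 40000 nM.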

Compound 3, half-maximal inhibitory concentration: 9800 nM
Estimate against measurement, compound 3: 2.0-fold (0.31 log units) above; measured number inside the range.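

In this assay compound 3 gives 9800 nM, the only actual number among the compounds shown, so the amide-type nitrogen now has one measured substituent to compare against. Pyridin-2-yl in place of 4-chlorophenyl gives an at least 2.0-fold lower number from compound 2 to compound 3 (0.30 log units; that floor lies within the scatter), and (pyridin-2-yl)amino in place of piperidin-1-yl on a carbonyl carbon gives an at least 2.0-fold lower number from compound 1 to compound 3 (0.30 log units; that floor lies within the scatter). Both steps are floors, so their true sizes remain unknown, and the other two compounds still report only a limit of the assay: the limit of > 20000 nM in this assay, at which 2 of the 3 values shown sit.

As far as these compounds go, it remains open whether the ring nitrogen of pyridin-2-yl or the loss of the chlorine matters here, a question that plain phenyl or pyridin-3-yl on the same amide-type nitrogen would address. The compounds shown all share one core, so the effect of any change to it is also open.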